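Trimming the acid side chain of compound 2

The compounds below may be only part of what the source reports. "The series", "measured", "known", "first", "only" and "open" are said of these compounds alone.

In a functional assay on PC-3 cells (Homo sapiens), read by MTT assay, with a stated time of 48 h (a lower number here means a stronger inhibitor, a higher number a weaker inhibitor), compound 2 `CC[C@@H](C)[C@H](NC(=O)c1ccc(C(CC)(CC)c2ccc(OCC(=O)C(C)(C)C)c(C)c2)n1CC)C(=O)O` gives 1600 nM and compound 1 `CCN(CC)CCCNC(=O)c1ccc(C(CC)(CC)c2ccc(OCC(=O)C(C)(C)C)c(C)c2)n1CC` gives 1800 nM so the two stand level within the scatter. Compound 3 `CCn1c(C(=O)N(C)CC(=O)O)ccc1C(CC)(CC)c1ccc(OCC(=O)C(C)(C)C)c(C)c1` keeps the shared core and differs from compound 2 only on the carbonyl carbon (carboxymethyl)(methyl)amino in place of (1-carboxy-2-methylbutyl)amino on a carbonyl carbon and neither group contains a ring or carries a net charge. For the measured compounds named here, only one measured step bears on this change. That step is a 1.1-fold lower number from compound 1 to compound 2 (0.05 log units; within the scatter) and it swaps 3-(diethylamino)propyl for 1-carboxy-2-methylbutyl on the same amide-type nitrogen, staying within the scatter. Going by the values given here, no measured compound carries the new group, so this evidence is thin and the range must stay wide. Nothing beyond the scatter is expected in this assay for this change. The expected change is a 1.2-fold higher number from compound 2 to compound 3 (0.07 log units; within the scatter) and no more. The estimated value for compound 3 is 1900 nM (range 700 nM to 5000 nM).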

Compound 3, half-maximal inhibitory concentration: 18400 nM
Estimate against measurement, compound 3: 9.7-fold (0.99 log units) below; the whole stated range lies below it.
By their numbers in this assay, from the lowest: compounds 2 and 1 (each within the scatter of the next); then compound 3.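

In this assay the group on this carbonyl carbon proves to matter: the earlier pair gave no sign of that, yet (carboxymethyl)(methyl)amino in place of (1-carboxy-2-methylbutyl)amino gives a 12-fold higher number from compound 2 to compound 3 (1.06 log units; beyond the scatter) and so a much weaker compound. The comparison with the basic-amine side chain agrees, with a 10-fold higher number from compound 1 to compound 3 (1.01 log units; beyond the scatter) on replacing (3-(diethylamino)propyl)amino, so compound 3 stands apart from two compounds that sit level with each other. The data shown offer no explanation for this drop.

This change removes the amide hydrogen and shortens the side chain in a single step, so the two effects cannot be told apart here. A (carboxymethyl)amino group, which keeps the amide hydrogen, would separate them, and a longer chain carrying the carboxylic acid on the methylated nitrogen would test the chain length alone.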